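Ring Expansion at the Amine of a Shared Core

A few compounds are considered here, and "the series" means these few. Any claim that something is new, unique, unknown or untested is made for them only; others in the source may bear on it.

Of the compounds shown here, three built on one core have been measured in a functional assay on PC-3 cells (Homo sapiens) for antiproliferative activity, read by MTT assay, with a stated time of 72 h; a lower number here means a stronger inhibitor, a higher number a weaker inhibitor. Compound 1 `CC(C)=CC(=O)Nc1cc2c(N3CCc4ccccc43)ncnc2cc1O[C@@H]1CCOC1` gives 4620 nM, compound 2 `C/C=C/C(=O)Nc1cc2c(N3CCc4ccccc43)ncnc2cc1O[C@@H]1CCOC1` gives 5220 nM, and compound 3 `CC/C=C/C(=O)Nc1cc2c(N3CCc4ccccc43)ncnc2cc1O[C@@H]1CCOC1` gives 9590 nM. Among them, compound 3 stands highest of the three numbers; the steps are a 1.1-fold higher number from compound 1 to compound 2 (0.05 log units; within the scatter), a 2.1-fold higher number from compound 1 to compound 3 (0.32 log units; beyond the scatter) and a 1.8-fold higher number from compound 2 to compound 3 (0.26 log units; within the scatter), so only the gap to compound 1 lies beyond the scatter.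

Compound 4 `CC/C=C/C(=O)Nc1cc2c(N3CCCc4ccccc43)ncnc2cc1O[C@@H]1CCOC1` keeps the chain of compound 3 on the carbonyl carbon and changes the other side of the core: 1,2,3,4-tetrahydroquinolin-1-yl in place of 2,3-dihydro-1H-indol-1-yl on an aromatic carbon. Going by the values given here, none of the measured steps bears on this change; all three vary the chain on the carbonyl carbon, and the group on the aromatic carbon is the same in compound 1, compound 2 and compound 3. With nothing to anchor a direction, the step is expected to be none beyond the scatter, a 1.0-fold higher number from compound 3 to compound 4 (0.02 log units; within the scatter). Compound 4 is therefore estimated at 10000 nM, with an expected range from 4000 nM to 25000 nM.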

Compound 4, half-maximal inhibitory concentration: 14300 nM
Compound 4: middle estimate off by 1.4-fold (0.16 log units), on the low side, within the range that was stated.
By their numbers in this assay, from the lowest: compounds 1, 2, 3 and 4 (each within the scatter of the next, the first and the last beyond it).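

In this assay, going by these compounds alone, the change of 2,3-dihydro-1H-indol-1-yl to 1,2,3,4-tetrahydroquinolin-1-yl gives a 1.5-fold higher number from compound 3 to compound 4 (0.17 log units; within the scatter), the first reading at this aromatic carbon, since the group there is the same in compounds 1, 2 and 3. Going from a five-membered to a six-membered non-aromatic ring at this position therefore produces no step that can be told from the scatter, with the but-1-en-1-yl chain held in place on the carbonyl carbon. Nothing measured on these two groups bears on the result.

As far as these compounds go, whether the same ring change reads alike with the prop-1-en-1-yl or 2-methylprop-1-en-1-yl chain remains open. So does the effect of a different kind of group on this carbon, such as an open-chain dimethylamino group or a morpholine.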